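The source may report more compounds than this note shows. Statements on the series, on what has been measured and on what is new or still open speak of the compounds shown alone.

In an assay on 3T3-L1 cells for inhibition of diacylglycerol O-acyltransferase 1 (Mus musculus) (a lower number here means a stronger inhibitor, a higher number a weaker inhibitor), compound 1 `CN(C)C(=O)C(C)(C)COc1nnc(-c2ccc(NC(=O)c3ccc4ccccc4c3)cc2)n1C` gives 440 nM, and compound 3 `Cc1cc(NC(=O)c2ccc3ccccc3c2)ccc1-c1cnc(OCC(C)(C)C(=O)O)nc1` gives 433 nM. Compound 2 `Cc1ccc(C(=O)Nc2ccc(-c3nnc(SC(C)C(=O)O)n3C)cc2)cc1` returns only a limit, > 20000 nM, in this assay. Compound 2 thus sits at the limit of > 20000 nM in this assay, at which 1 of the 3 values shown sits, with no number of its own, at the weak end of the three results shown. Compound 4 `CC(Sc1nnc(-c2ccc(NC(=O)c3ccccc3)cc2)n1C)C(=O)O` has not yet been measured in this assay. It differs from compound 2 in one place: hydrogen in place of methyl on an aromatic carbon. Among the compounds with values here, no measured pair shows a step of this kind, so its size is uncertain, but the change is expected to leave the result of compound 2 essentially unchanged, with a step that the limit leaves unreadable from compound 2 to compound 4 expected to stay within the scatter. Compound 4 is therefore expected to give about 25000 nM in this assay, within a range from 8000 nM to 80000 nM, most likely again reported only as a limit.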

Compound 4, half-maximal inhibitory concentration: > 20000 nM
Compound 4: no number, only a limit (the forecaster's own chance of this, stated with the estimate: 80%); the middle value does not contradict the limit.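

Like compound 2, compound 4 returns only a limit (> 20000 nM) in this assay and so no step between the two can be read. The compounds shown leave open whether hydrogen in place of methyl on an aromatic carbon changes the result where a number can be read.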